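Cyclohexyl for cyclopentyl on the shared core

The source may hold more compounds than are shown below. What is called first, only, known or untested is meant among the compounds shown, and "the series" means these compounds.

Going by the values given here, compound 3 `COC(=O)c1nc(C2CCCC2)n(-c2ccc(C(F)(F)F)cc2)n1` gives 5710 nM in a functional assay on NCI-H226 cells (Homo sapiens) for inhibition, read by MTT assay, with a stated time of 72 h (on this read-out lower numbers stand for stronger inhibition of growth and higher numbers for weaker inhibition of growth), the lowest of the three numbers so far. Compound 2 `COC(=O)c1nc(C2CCCCC2)n(-c2ccc(F)cc2)n1` gives 6260 nM in this assay, within the scatter of compound 3, while compound 1 `COC(=O)c1nc(C)n(-c2ccc(C(F)(F)F)cc2)n1` gives 16600 nM. Among the compounds with values here, the one single-point step measured, a 2.9-fold lower number from compound 1 to compound 3 (0.46 log units; beyond the scatter), is modest. Compound 4 `COC(=O)c1nc(C2CCCCC2)n(-c2ccc(C(F)(F)F)cc2)n1` differs from compound 3 by cyclohexyl in place of cyclopentyl on an aromatic carbon. Within the data shown here, no measured step covers this change; the only pointer is compound 2, which also carries cyclohexyl and gives 6260 nM in this assay, within the scatter of compound 3, so no step beyond the scatter is expected. For compound 4 the estimate is 5000 nM (range 2500 nM to 10000 nM), meaning an expected step of a 1.1-fold lower number from compound 3 to compound 4 (0.06 log units; within the scatter).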

Compound 4, concentration for 50% growth inhibition: 5760 nM
Estimate against measurement, compound 4: 1.2-fold (0.06 log units) below; measured number inside the range.
By their numbers in this assay, from the lowest: compounds 3, 4 and 2 (each within the scatter of the next); then compound 1.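

In this assay, cyclopentyl and cyclohexyl on this aromatic carbon cannot be told apart (a 1.0-fold higher number from compound 3 to compound 4 (0.00 log units; within the scatter)). With cyclohexyl in place, trifluoromethyl and fluoro also cannot be separated (a 1.1-fold lower number from compound 2 to compound 4 (0.04 log units; within the scatter)), while the modest step away from methyl, first seen with cyclopentyl, appears again with cyclohexyl (a 2.9-fold lower number from compound 1 to compound 4 (0.46 log units; beyond the scatter)). No measurement shown offers an explanation for these steps.

On these data alone, whether an isopropyl, phenyl or amine group at this carbon would keep the number close to those of compound 3 and compound 4 stays open. As far as these compounds go, the effect of a carboxylic acid in place of the methoxycarbonyl group also stays open.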